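Notes on the urea step from compound 2

This account rests on a few compounds, and the source may have more. Where it says the series, first, only, none or still open, it means among the compounds named here.

Measured in a physicochemical assay for solubility; on this read-out lower numbers stand for lower solubility and higher numbers for higher solubility:
compound 1 (`CC(C)(C)OC(=O)N1C(=O)CC[C@H]1C(=O)N1CCC(NS(=O)(=O)c2cc(S(=O)(=O)c3ccccc3)ccc2C(F)(F)F)CC1`): 50000 nM
compound 2 (`CC(C)C(=O)N1CCC[C@H]1C(=O)N1CCC(NS(=O)(=O)c2cc(S(=O)(=O)c3ccccc3)ccc2C(F)(F)F)CC1`): 100000 nM

Only these two numbers are available so far. Compound 2 (100000 nM) lies within the usual scatter of compound 1 (50000 nM), so the pair does not separate. Going by the values given here, the two also differ in more than one place, which means they offer no clean step.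

The next compound to be read is compound 3 (`O=C([C@@H]1CCCN1C(=O)Nc1ccccc1)N1CCC(NS(=O)(=O)c2cc(S(=O)(=O)c3ccccc3)ccc2C(F)(F)F)CC1`). It differs from compound 2 in one place (anilino in place of isopropyl on a carbonyl carbon): anilino in place of isopropyl on a carbonyl carbon whose other neighbours are an amide-type nitrogen in a ring. The same difference, cut one bond further out, reads isopropylcarbonyl to phenylcarbamoyl.

Among the compounds with values here, no measured pair shows this change, so the expectation rests on the structural change alone and is a weak one. In this assay a moderate fall, somewhat beyond the scatter, is expected. The estimated step is a lowering (a 3.3-fold lower number from compound 2 to compound 3 (0.52 log units; beyond the scatter)). For compound 3 the expected value is 30000 nM with an estimated range from 8000 nM to 90000 nM at the time of reading.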

Compound 3, solubility: 25000 nM
Beside the measured number, compound 3's estimate is 1.2-fold (0.08 log units) above it; measured number inside the range.
By their numbers in this assay, from the lowest: compounds 3, 1 and 2 (each within the scatter of the next, the first and the last beyond it).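

Notes after the urea step

In this assay, the carbonyl carbon whose other neighbours are an amide-type nitrogen in a ring now has its first one-place reading: isopropyl to anilino gives a 4.0-fold lower number from compound 2 to compound 3 (0.60 log units; beyond the scatter), a modest step. Compound 1 and compound 2 differ in more than one place and did not separate, so they could say nothing about this position, whereas this pair shows that a change here alone can move the number past the scatter. The anilino group brings an aromatic ring, a hydrogen-bond donor and a larger heavy-atom count in a single change, and nothing available here bears on the reason for the step.

Which of those features goes with the lower number stays open: a benzyl group on the same carbonyl carbon would keep an aromatic ring without the amide hydrogen, while a cyclohexylamino group would keep that hydrogen without an aromatic ring. As far as these compounds go, with a single pair, it also stays open whether substituents on the phenyl ring of the anilino group, such as a carboxylic acid or a dimethylamino group, would shift the number further in either direction.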